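The compounds below may be only part of what the source reports. "The series", "measured", "known", "first", "only" and "open" are said of these compounds alone.

Working notes on the series, read in an ADME assay on MT4 cells (Homo sapiens) for cytotoxicity, with a stated time of 5 days; on this read-out lower numbers stand for higher toxicity in this test and higher numbers for lower toxicity in this test. Compound 1 `CC(C)(C)C#Cc1cc(N(C(=O)[C@H]2CC[C@H](C)CC2)[C@H]2CC[C@H](OC3COC3)CC2)c(C(=O)O)s1` gives 8350 nM, compound 2 `CC(C)(C)C#Cc1cc(N(C(=O)[C@H]2CC[C@H](C)CC2)[C@H]2CC[C@H](OC3CCOC3)CC2)c(C(=O)O)s1` gives 3070 nM, and compound 3 `C[C@@H]1CC[C@@H](C(=O)N(c2cc(C#CC(C)(C)C)sc2C(=O)O)[C@H]2CC[C@H](OC3CCOC3)CC2)[C@@H](O)C1` gives 11600 nM. Compound 2 holds the lowest number of the three, and its steps to both other compounds lie beyond the scatter.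

The next compound to read is compound 4 `CC(C)(C)C#Cc1cc(N(C(=O)[C@H]2CC[C@H](C)CC2)[C@H]2CC[C@H](Oc3ccccn3)CC2)c(C(=O)O)s1`, which differs from compound 2 in one place: pyridin-2-yl in place of oxolan-3-yl on an oxygen on a saturated carbon. This puts pyridin-2-yl in place of oxolan-3-yl on an oxygen on a saturated carbon.

For the measured compounds named here, two measured steps bear on this change. The closer one acts at the same place, exchanging oxetan-3-yl for oxolan-3-yl: a 2.7-fold lower number from compound 1 to compound 2 (0.43 log units; beyond the scatter). The other adds hydroxy in place of hydrogen on a saturated ring carbon, a different place, and so bears less directly: a 3.8-fold higher number from compound 2 to compound 3 (0.58 log units; beyond the scatter). Going by the values given here, no measured compound carries an aromatic ring on this oxygen, so the direction is weakly fixed. A small move towards a lower number is expected in this assay, with no clear change beyond the scatter.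

The estimated step is a 1.4-fold lower number from compound 2 to compound 4 (0.14 log units; within the scatter). In this assay the estimated value for compound 4 is 2200 nM, with an expected range of 800 nM to 6000 nM.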

Compound 4, half-maximal cytotoxic concentration: 100 nM
The estimate for compound 4 lay 22-fold (1.34 log units) above the measured number; the whole stated range lies above it.
By their numbers in this assay, from the lowest: compound 4; then compound 2; then compounds 1 and 3 (each within the scatter of the next).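

At this position on the oxygen, the response in this assay is far larger than the exchange of saturated rings indicated: a 2.7-fold lower number from compound 1 to compound 2 (0.43 log units; beyond the scatter) for oxolan-3-yl in place of oxetan-3-yl, but a 31-fold lower number from compound 2 to compound 4 (1.49 log units; beyond the scatter) for pyridin-2-yl in place of oxolan-3-yl and an 84-fold lower number from compound 1 to compound 4 (1.92 log units; beyond the scatter) for pyridin-2-yl in place of oxetan-3-yl. Oxolan-3-yl and pyridin-2-yl carry the same counts of hydrogen-bond donors and acceptors and no net charge, so these counts do not separate them, whereas the ring size and aromatic character do differ. Nothing measured here accounts for the size of this step.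

The compounds shown do not separate the contribution of the aromatic ring from that of its nitrogen, a question that phenyl or pyridin-3-yl on the same oxygen would address. As far as these compounds go, it also remains open whether the hydroxy group on the saturated ring carbon, which gave a 3.8-fold higher number from compound 2 to compound 3 (0.58 log units; beyond the scatter) alongside oxolan-3-yl, would have a similar effect alongside pyridin-2-yl.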